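This account rests on a few compounds, and the source may have more. Where it says the series, first, only, none or still open, it means among the compounds named here.

- Compound 1 `CCC(C(=O)N[C@@H](CC(=O)O)C(=O)CSCc1ccccc1)n1ccnc(NCC2COc3ccccc3O2)c1=O`: 30 nM
- Compound 2 `CCC(C(=O)N[C@@H](CC(=O)O)C(=O)CSCc1ccccc1)n1ccnc(NCc2cc(C)no2)c1=O`: 6.41 nM

Going by the values given here, in a functional assay on NT2 cells (Homo sapiens) for inhibition (a higher number here means a weaker inhibitor, a lower number a stronger inhibitor), compound 2, at 6.41 nM, has the lower of the two numbers so far. Among the compounds with values here, its only neighbour is compound 1, at 30 nM. Within the data shown here, the single measured step is a 4.7-fold lower number from compound 1 to compound 2 (0.67 log units; beyond the scatter). That modest step came with 3-methyl-1,2-oxazol-5-yl in place of 2,3-dihydro-1,4-benzodioxin-2-yl.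

Compound 3 `CCC(C(=O)N[C@@H](CC(=O)O)C(=O)CSCc1ccccc1)n1ccnc(NCc2nc(C)no2)c1=O` changes the same place again, with 3-methyl-1,2,4-oxadiazol-5-yl in place of 3-methyl-1,2-oxazol-5-yl on a saturated chain carbon bound to a nitrogen on an aromatic ring. This swap is a much closer one, with one five-membered aromatic ring replacing another. No measurement tests it directly, and the measured step involved a very different group, so that step offers only a loose guide to size. A small change is therefore expected in this assay, probably within the scatter and, if anything, slightly upward. The expected step is a 1.2-fold higher number from compound 2 to compound 3 (0.10 log units; within the scatter). The estimate for compound 3 is 8 nM, with an expected range from 3 nM to 22 nM.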

Compound 3, half-maximal inhibitory concentration: 5.33 nM
For compound 3 the middle estimate is 1.5-fold (0.18 log units) above the measured one; measured number inside the range.
By their numbers in this assay, from the lowest: compounds 3 and 2 (each within the scatter of the next); then compound 1.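

In this assay, exchanging one five-membered aromatic ring for another gives a 1.2-fold lower number from compound 2 to compound 3 (0.08 log units; within the scatter), so 3-methyl-1,2,4-oxadiazol-5-yl, with 3 hetero atoms, and 3-methyl-1,2-oxazol-5-yl, with 2, cannot be told apart at this position, on a saturated chain carbon bound to a nitrogen on an aromatic ring. The new ring also gives a 5.6-fold lower number from compound 1 to compound 3 (0.75 log units; beyond the scatter), which shows that the advantage over the 2,3-dihydro-1,4-benzodioxin-2-yl group of compound 1 is not unique to the ring in compound 2 and holds for both five-membered rings shown. No evidence is available here to explain these results.

From the compounds shown here alone, compound 2 and compound 3 both carry a methyl group on the five-membered ring, so its contribution remains unknown, and a version with hydrogen, ethyl or trifluoromethyl in its place would be needed to reveal it. Going by these compounds, it also remains open whether a five-membered aromatic ring is needed at all, a question that a six-membered pyridinyl ring or a simple open alkyl chain at this position could help answer.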